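Methoxy to methylsulfanyl: an expectation for compound 3

This account rests on a few compounds, and the source may have more. Where it says the series, first, only, none or still open, it means among the compounds named here.

Measured in a functional assay on MCF7 cells (Homo sapiens) for inhibition, read by resazurin assay, with a stated time of 72 h; a higher number here means a weaker inhibitor, a lower number a stronger inhibitor:
compound 1 `CCOc1ccc(C2C(C3CC3)C(=O)N2c2cc(OC)c(OC)c(OC)c2)cc1`: 131 nM
compound 2 `COc1ccc(C2C(C3CC3)C(=O)N2c2cc(OC)c(OC)c(OC)c2)cc1`: 120 nM

For the measured compounds named here, compound 2, at 120 nM, stands within the scatter of the only other measured compound, compound 1 at 131 nM, so no order can be drawn between them.

The next compound to be measured is compound 3 `COc1cc(N2C(=O)C(C3CC3)C2c2ccc(SC)cc2)cc(OC)c1OC`. Its difference from compound 2 is methylsulfanyl in place of methoxy on an aromatic carbon. In words, methylsulfanyl takes the place of methoxy on an aromatic carbon, para to a large group.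

Going by the values given here, only one measured step lies near this change: a 1.1-fold lower number from compound 1 to compound 2 (0.04 log units; within the scatter). That step, hydrogen in place of methyl on a saturated chain carbon bound to an oxygen on an aromatic ring, stayed within the scatter. Among the compounds with values here, it retains the oxygen, however, and no measured step replaces it, so the evidence for the new change is indirect.

A small change is therefore expected, with no firm direction and nothing clearly beyond the scatter. The expected step is a 1.4-fold higher number from compound 2 to compound 3 (0.15 log units; within the scatter). The estimate in this assay for compound 3 is 170 nM, with an expected range of 55 nM to 520 nM.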

Compound 3, half-maximal inhibitory concentration: 131 nM
The estimate for compound 3 lay 1.3-fold (0.11 log units) above the measured number, and the stated range covers the measured number.
By their numbers in this assay, from the lowest: compounds 2, 1 and 3 (each within the scatter of the next).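

For the compounds shown here, compound 3 is the first compound in which the oxygen on the aromatic carbon, para to a large group, is replaced rather than kept, and in this assay the exchange of methoxy for methylsulfanyl gives a 1.1-fold higher number from compound 2 to compound 3 (0.04 log units; within the scatter) while the exchange of ethoxy for methylsulfanyl gives no change at the digits printed from compound 1 to compound 3 (within the scatter) in the same series. The earlier pair had shown only that the chain on the oxygen could be shortened within the scatter, whereas these steps show that the oxygen itself can give way to sulfur with no change beyond the scatter, so that all three compounds now stand within the scatter of one another at this place. No independent measurement bears on this result, and the data offer no account of it.

From the compounds shown here alone, whether an amine, a carboxylic acid or a longer chain on this aromatic carbon would move the number beyond the scatter remains open. Also open, going by these compounds, is whether the exchange of methoxy for methylsulfanyl would read the same way in another cell line or with other groups on the shared core.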